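Working notes on the step from compound 3 to compound 4

The compounds below may be only part of what the source reports. "The series", "measured", "known", "first", "only" and "open" are said of these compounds alone.

Three compounds of the series, compound 1 `COc1ccccc1CN(C)Cc1ccc(/C=C2\Oc3cc(OC)c(OC)cc3C2=O)cc1O`, compound 2 `COc1cc2c(cc1OC)C(=O)/C(=C/c1ccc(CN(C)Cc3ccccc3)c(O)c1)O2` and compound 3 `COc1cc2c(cc1OC)C(=O)/C(=C/c1cccc(O)c1)O2`, have been run in an assay on cells for inhibition of Amine oxidase [flavin-containing] A (Homo sapiens), read by fluorescence, with a stated time of 30 min, tested at 10 uM; on this read-out higher numbers stand for more inhibition at the one concentration tested (going by the name of the read-out) and lower numbers for less inhibition. Compound 1 gives 16.3%, compound 2 gives 19.4% and compound 3 gives 17.2%. Compound 3 therefore stands second highest of the three numbers; its nearest neighbour is compound 1 and its furthest is compound 2, and both gaps lie within the scatter. The two single-change steps are a number 3.1 percentage points higher from compound 1 to compound 2 (within the scatter), with hydrogen in place of methoxy on an aromatic carbon, and a number 2.2 percentage points lower from compound 2 to compound 3 (within the scatter), with hydrogen in place of (benzyl(methyl)amino)methyl on an aromatic carbon. Compound 4 `COc1cc2c(cc1OC)C(=O)/C(=C/c1ccc(CN3CCCCC3)c(O)c1)O2` differs from compound 3 by (piperidin-1-yl)methyl in place of hydrogen on an aromatic carbon. The step that bears on it is a number 2.2 percentage points lower from compound 2 to compound 3 (within the scatter), which in the reverse sense shows that entry of an aminomethyl group at this carbon gave no change beyond the scatter. Compound 4 is therefore expected to show no step beyond the scatter, a number 0.8 percentage points higher from compound 3 to compound 4 (within the scatter), in this assay . The estimate for compound 4 is 18%, within 9% to 28%.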

Compound 4, a percentage reported as inhibition, at one concentration (the size of the read-out at that concentration, not a potency): 15.3%
The estimate for compound 4 lay 2.7 percentage points above the measured number, and the stated range covers the measured number.
By their numbers in this assay, from the lowest: compounds 4, 1, 3 and 2 (each within the scatter of the next).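

In this assay, the aromatic carbon ortho to the hydroxy group takes (piperidin-1-yl)methyl in place of hydrogen with a number 1.9 percentage points lower from compound 3 to compound 4 (within the scatter), so a ring amine, like the open-chain amine of compound 2, leaves the number within the scatter. Exchanging the amine on the saturated chain carbon also shows no step beyond the scatter: piperidin-1-yl in place of benzyl(methyl)amino gives a number 4.1 percentage points lower from compound 2 to compound 4 (within the scatter), and piperidin-1-yl in place of (2-methoxybenzyl)(methyl)amino gives a number 1 percentage points lower from compound 1 to compound 4 (within the scatter). No supporting data are available to explain why these numbers stay so close.

The compounds shown leave open whether any group at this position can move the number beyond the scatter. From the compounds shown here alone, a morpholin-4-yl or dimethylamino group on the same saturated chain carbon remains untested here, as does a carboxylic acid in that place.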